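A Carbonyl Swap Where Both Measured Compounds Show No Inhibition

The source may hold more compounds than are shown below. What is called first, only, known or untested is meant among the compounds shown, and "the series" means these compounds.

Compound 1 `CCCC(=O)n1nc(C)c(-c2ccc(Cl)c(Cl)c2)c1N` was tested in an assay on Sf9 cells for inhibition of mitogen-activated protein kinase kinase kinase 14 (Homo sapiens), read by ADP-Glo, with a stated time of 60 min; on this read-out lower numbers stand for stronger inhibition and higher numbers for weaker inhibition. Compound 1 gives only a limit of the assay, > 100000 nM. Compound 2 `CCc1nn(C(C)=O)c(N)c1-c1ccc(Cl)c(Cl)c1` likewise gives only a limit, > 100000 nM. For the measured compounds named here, both measured compounds therefore stand at the limit of > 100000 nM in this assay, at which 2 of the 2 values shown sit, and no measured step exists to compare. Compound 3 `Cc1nn(C(=O)OC(C)(C)C)c(N)c1-c1ccc(Cl)c(Cl)c1` differs from compound 1 by tert-butoxy in place of propyl on a carbonyl carbon. With no inhibition seen so far, no change beyond the usual scatter is expected, and compound 3 is expected to stay at or near the same ceiling. Compound 3 is estimated at 150000 nM, between 50000 nM and 500000 nM. The expected step is a step that the limit leaves unreadable from compound 1 to compound 3.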

Compound 3, half-maximal inhibitory concentration: > 100000 nM
Compound 3: only a limit was reported (the forecaster's own chance of this, stated with the estimate: 85%); the middle value lies beyond the limit too.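

For the compounds shown here, compound 3, like compound 1, gives only a limit of the assay, so no step between these two compounds can be read. The compounds shown leave open which group on this carbonyl carbon, if any, would give a measurable value.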